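The compounds below may be only part of what the source reports. "The series", "measured", "known", "first", "only" and "open" are said of these compounds alone.

Measured so far:
compound 1 `CC[C@@H](C)[C@H](N)CN(C(=O)[C@@H]1C[C@H]1c1ccccc1)c1ccc(-c2ccccc2)cc1` gives 1.4 nM in a functional assay for agonist activity at G protein-coupled receptor 88 (Homo sapiens), read by HTRF and cAMP accumulation; on this read-out higher numbers stand for an effect only at larger amounts of compound and lower numbers for an effect already at smaller amounts;
compound 2 `CC(C)CCNCCN(C(=O)[C@@H]1C[C@H]1c1ccccc1)c1ccc(-c2ccccc2)cc1` gives 5.1 nM;
compound 3 `CC[C@H](C)[C@H](N)CN(C(=O)[C@@H]1C[C@H]1c1ccccc1F)c1ccc(-c2ccccc2)cc1` gives 650 nM.

Compound 3 carries the highest number of the three; its gap to compound 2 and its gap to compound 1 both lie well beyond the scatter. Compound 4 `CC[C@H](C)[C@H](N)CN(C(=O)[C@@H]1C[C@H]1c1ccsc1)c1ccc(-c2ccccc2)cc1` is not yet measured. It differs from compound 3 by thiophen-3-yl in place of 2-fluorophenyl on a saturated ring carbon.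

For the measured compounds named here, the only step between measured compounds that differ in one place is a 3.6-fold higher number from compound 1 to compound 2 (0.56 log units; beyond the scatter), and that step sits on the saturated chain carbon bound to the amide-type nitrogen, not on the three-membered ring, so it does not bear directly on the present change. Going by the values given here, no step is recorded between compound 1 and compound 3; their values show only that the two differ widely. Among the compounds with values here, a thiophen-3-yl in place of 2-fluorophenyl on the saturated ring carbon therefore has no precedent in this set, and the expected step of a 2.2-fold lower number from compound 3 to compound 4 (0.34 log units; beyond the scatter) rests on the shared core alone: a change within the scatter or a modest drift is expected, with wide uncertainty.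

Compound 4 is estimated at 300 nM, within a range of 60 nM to 2000 nM.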

Compound 4, half-maximal effective concentration: 450 nM
For compound 4 the middle estimate is 1.5-fold (0.18 log units) below the measured one; the measured number falls inside the stated range.
By their numbers in this assay, from the lowest: compound 1; then compound 2; then compounds 4 and 3 (each within the scatter of the next).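

In this assay, for the compounds shown here, this is the first reading at this position: thiophen-3-yl in place of 2-fluorophenyl on a saturated ring carbon of the three-membered ring gives a 1.4-fold lower number from compound 3 to compound 4 (0.16 log units; within the scatter). The exchange therefore replaces a six-membered aromatic ring of carbon only, with 7 heavy atoms and a fluorine, by a five-membered aromatic ring with 1 hetero atom and 5 heavy atoms, and no readable shift in the number follows, at least for this pair on this core. No measurement is available that would account for this outcome.

One pair cannot show whether the position tolerates exchanges in general, so a thiophen-2-yl, a pyridin-3-yl or a 4-fluorophenyl on the same saturated ring carbon remains an open case. Compound 3 differs in more than one place from compound 1, which gives 1.4 nM, and the compounds shown do not separate which of those differences goes with the wide gap in their printed values.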